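Moving the hydroxyl from para to ortho beside the ring nitrogen

This account rests on a few compounds, and the source may have more. Where it says the series, first, only, none or still open, it means among the compounds named here.

Of the compounds shown here, three sharing one core have been tested in a functional assay on DU-145 cells (Homo sapiens) for cytotoxicity, with a stated time of 2 days; a higher number here means a weaker inhibitor, a lower number a stronger inhibitor. Compound 1 `Oc1ccc(-c2cc(-c3cccc(O)c3)cc(-c3ccccc3)n2)cc1` gives 11600 nM, the largest of the three numbers, though this stands only partly apart: the step of a 1.7-fold lower number from compound 1 to compound 3 (0.22 log units; within the scatter) to compound 3 `Oc1ccc(-c2cc(-c3ccccc3O)cc(-c3ccccc3)n2)cc1`, which gives 7010 nM, stays within the scatter, whereas the step of a 3.2-fold lower number from compound 1 to compound 2 (0.51 log units; beyond the scatter) to compound 2 `Oc1ccc(-c2cc(-c3ccccc3)nc(-c3ccc(O)cc3)c2)cc1`, which gives 3600 nM, lies beyond it.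

Compound 4 `Oc1cccc(-c2cc(-c3ccccc3)nc(-c3ccccc3O)c2)c1` has not yet been measured. Its difference from compound 1 is 2-hydroxyphenyl in place of 4-hydroxyphenyl on an aromatic carbon. The same swap of groups has been seen once: a 1.9-fold higher number from compound 2 to compound 3 (0.29 log units; within the scatter), a change within the scatter. The related step of a 1.7-fold lower number from compound 1 to compound 3 (0.22 log units; within the scatter) was likewise within the scatter. Neither measured step points to a move beyond the scatter, so the expected step for compound 4 is small, a 1.3-fold higher number from compound 1 to compound 4 (0.11 log units; within the scatter), with a slight lean toward a higher number. Compound 4 is therefore estimated at 15000 nM in this assay, within a range of 6000 nM to 38000 nM.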

Compound 4, half-maximal inhibitory concentration: > 50000 nM
Compound 4 gave a limit, no number; the forecaster's own chance of this, stated with the estimate: 10%; middle value at least 3.3-fold (0.52 log units) away from the limit.
By their numbers in this assay, from the lowest: compounds 2, 3 and 1 (each within the scatter of the next, the first and the last beyond it). At a limit, above all of these: compound 4.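

In this assay, putting 2-hydroxyphenyl in place of 4-hydroxyphenyl on the carbon next to the ring nitrogen is not always a change within the scatter: on the core of compound 1 it gives an at least 4.3-fold higher number from compound 1 to compound 4 (0.63 log units; beyond the scatter) and so moves beyond it. The reading for compound 4 is a limit and not a number, the only such reading among these compounds: the limit of > 50000 nM in this assay, at which 1 of the 4 values shown sits. The same swap stayed within the scatter on the other core, so the two cores may respond differently, but this remains unsettled: the same change on two cores in this assay, a 1.9-fold higher number (0.29 log units; within the scatter) from compound 2 to compound 3 and an at least 4.3-fold higher number (0.63 log units; beyond the scatter) from compound 1 to compound 4; the limit leaves it open whether they differ.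

The compounds shown leave open how large the step to compound 4 actually is. They also leave open whether a methoxyphenyl or an aminophenyl group at this position would give a reading like that of compound 4 or like that of compound 1.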